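Swapping 2,4-dichlorophenyl for ethoxycarbonyl on a carbonyl carbon

A few compounds are considered here, and "the series" means these few. Any claim that something is new, unique, unknown or untested is made for them only; others in the source may bear on it.

Among the compounds with values here, in a functional assay on Vero cells (Chlorocebus sabaeus) for inhibition (a lower number here means a stronger inhibitor, a higher number a weaker inhibitor), compound 3 `COc1cc(/C=C/C(=O)c2cccc(NC(=O)c3ccc(Cl)cc3Cl)c2)ccc1O` gives 27.2 ug/mL, the highest number and so the weakest inhibitor of the three measured so far. Compound 1 `COc1cc(/C=C/C(=O)c2cccc(NC(=O)c3ccc(Cl)cc3)c2)ccc1O` gives 3.82 ug/mL and compound 2 `COc1cc(/C=C/C(=O)c2cccc(N)c2)ccc1O` gives 6.02 ug/mL, and these two are separated only by a 1.6-fold higher number from compound 1 to compound 2 (0.20 log units; within the scatter).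

Compound 4 `CCOC(=O)C(=O)Nc1cccc(C(=O)/C=C/c2ccc(O)c(OC)c2)c1` carries ethoxycarbonyl in place of 2,4-dichlorophenyl on a carbonyl carbon. Within the data shown here, no measured step makes this exact change, so the evidence is indirect. Adding one chloro gave a 7.1-fold higher number from compound 1 to compound 3 (0.85 log units; beyond the scatter), and placing (2,4-dichlorophenyl)carbonyl on the nitrogen gave a 4.5-fold higher number from compound 2 to compound 3 (0.65 log units; beyond the scatter). Both steps are modest and both end at the 2,4-dichlorophenyl group, which compound 4 lacks. On these data alone, a modest move back to a lower number therefore seems likely, although ethoxycarbonyl itself is untested here. The expected change is a 2.7-fold lower number from compound 3 to compound 4 (0.43 log units; beyond the scatter). Compound 4 is estimated at 10 ug/mL, with an expected range of 3.5 ug/mL to 30 ug/mL.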

Compound 4, half-maximal inhibitory concentration: > 50 ug/mL
Compound 4 ended at the assay's limit (the forecaster's own chance of this, stated with the estimate: 5%); middle value at least 5.0-fold (0.69 log units) away from the limit.
By their numbers in this assay, from the lowest: compounds 1 and 2 (each within the scatter of the next); then compound 3. At a limit, above all of these: compound 4.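

In this assay compound 4 gives > 50 ug/mL, which is a limit of the assay and not a number: the limit of > 50 ug/mL in this assay, at which 1 of the 4 values shown sits. Until now, only aryl groups had been seen on this carbonyl carbon, and replacing the ring with a non-ring group does not hold the level of the parent compounds: (ethoxycarbonyl)carbonyl on the nitrogen gives an at least 8.3-fold higher number from compound 2 to compound 4 (0.91 log units; beyond the scatter), and ethoxycarbonyl in place of 4-chlorophenyl gives an at least 13-fold higher number from compound 1 to compound 4 (1.11 log units; beyond the scatter). Against the 2,4-dichlorophenyl amide, the reading is only an at least 1.8-fold higher number from compound 3 to compound 4 (0.26 log units; that floor lies within the scatter), so this floor does not separate those two.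

The compounds shown leave open how far beyond the limit the true value of compound 4 lies. They also leave open whether losing the ring or adding the ester matters more, which a plain phenyl, a methyl or a carboxylic acid on the same carbonyl carbon could help to settle.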